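A few compounds are considered here, and "the series" means these few. Any claim that something is new, unique, unknown or untested is made for them only; others in the source may bear on it.

Values measured so far in a functional assay on the whole organism with Mus musculus as the target, in the rotarod test; a higher number here means that more compound is needed for the effect, a lower number that less compound is needed
- compound 1 `CC(=O)NCC(=O)Nc1ccc(Cl)cc1C(=O)c1ccccc1` gives > 100 mg/kg as a limit, not a number
- compound 2 `CCCCCC(=O)NCC(=O)N(C)c1ccc(Cl)cc1C(=O)c1ccccc1Cl` gives 90 mg/kg as a number
- compound 3 `CN(C(=O)CNC(=O)CN)c1ccc([N+](=O)[O-])cc1C(=O)c1ccccc1` gives 2.94 mg/kg as a number

Of the two true numbers, compound 2 holds the higher, and compound 3 lies lower by a gap beyond the scatter. Compound 4 `CC(=O)NCC(=O)N(C)c1ccc(Cl)cc1C(=O)c1ccccc1Cl` differs from compound 2 by hydrogen in place of butyl on a saturated chain carbon bound to a carbonyl carbon in one place, with hydrogen in place of butyl on a saturated chain carbon bound to a carbonyl carbon, so pentylcarbonyl becomes acetyl. Compound 1 also carries acetyl and gives the limit > 100 mg/kg in this assay as its only result. No shift beyond the scatter is therefore expected, and the estimated step of a 1.1-fold lower number from compound 2 to compound 4 (0.05 log units; within the scatter) is small. Compound 4 is expected at 80 mg/kg within an estimated range of 25 mg/kg to 250 mg/kg in this assay when measured.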

Compound 4, dose for half-maximal effect: 58 mg/kg
Beside the measured number, compound 4's estimate is 1.4-fold (0.14 log units) above it; measured number inside the range.
By their numbers in this assay, from the lowest: compound 3; then compounds 4 and 2 (each within the scatter of the next). At a limit, above all of these: compound 1.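

In this assay, for the compounds shown here, trimming pentylcarbonyl to acetyl gives a 1.6-fold lower number from compound 2 to compound 4 (0.19 log units; within the scatter), the first reading of this position. Replacing butyl with hydrogen on the saturated chain carbon bound to the carbonyl carbon thus leaves no shift that can be told from the scatter. Compound 1 stands at a limit, not a number: the limit of > 100 mg/kg in this assay, at which 1 of the 4 values shown sits.

From the compounds shown here alone, whether a chain longer than butyl or a carboxylic acid at this place would move the number remains open. Compound 3 differs from compound 4 in more than one place, so its value cannot be traced to any single change.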